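This account rests on a few compounds, and the source may have more. Where it says the series, first, only, none or still open, it means among the compounds named here.

Compound 1 is `O=C(NS(=O)(=O)c1ccccc1)c1cncc(Br)c1`. In a functional assay on MCF7 cells (Homo sapiens) for antiproliferative activity, read by MTT assay, with a stated time of 48 h (a higher number here means a weaker inhibitor, a lower number a stronger inhibitor), compound 1 gives 12900 nM. Compound 2, `O=C(NS(=O)(=O)c1ccc(F)cc1)c1cncc(Br)c1`, carries one change relative to compound 1: fluoro in place of hydrogen on an aromatic carbon. In this assay compound 2 gives 980 nM. That single change produced a 13-fold lower number from compound 1 to compound 2 (1.12 log units; beyond the scatter), a move that stands well beyond the usual run-to-run variation of this kind of measurement.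

Compound 3, `O=C(NS(=O)(=O)c1ccccc1)c1cccnc1Cl`, rests on a second core; how the core of compound 3 differs from the core of compound 1 is not broken down here. In this assay compound 3 gives 14000 nM, which is close to the number for compound 1 and gives no basis for ranking the two.

Compound 4, `O=C(NS(=O)(=O)c1ccc(F)cc1)c1cccnc1Cl`, has not yet been measured. It differs from compound 3 by fluoro in place of hydrogen on an aromatic carbon. Among the compounds with values here, this is the same change, at the same kind of place, as the one separating compound 1 from compound 2. Because that same change gave a 13-fold lower number from compound 1 to compound 2 (1.12 log units; beyond the scatter), the step from compound 3 to compound 4 is expected to be of similar size and direction. That expectation rests on one measured pair alone; with a single precedent, carried here by a different core, the size could come out smaller or larger than before. Compound 4 is therefore estimated at 1500 nM in this assay, which would mean a 9.3-fold lower number from compound 3 to compound 4 (0.97 log units; beyond the scatter), with a plausible range from 500 nM to 6000 nM.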

Compound 4, half-maximal inhibitory concentration: 12500 nM
Estimate against measurement, compound 4: 8.3-fold (0.92 log units) below; the measured number lies above the stated range.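

In this assay, fluoro in place of hydrogen on an aromatic carbon, para to a large group, gives a 1.1-fold lower number from compound 3 to compound 4 (0.05 log units; within the scatter), so on the core of compound 3 this change has no effect that can be told apart from ordinary measurement noise. Set beside the earlier pair, the result shows that the same change did not carry over from one core to the other in this assay: the same change on two cores in this assay, a 13-fold lower number (1.12 log units; beyond the scatter) from compound 1 to compound 2 and a 1.1-fold lower number (0.05 log units; within the scatter) from compound 3 to compound 4, 12-fold (1.07 log units) apart, beyond the scatter of two such steps. The large step seen on the core of compound 1 therefore cannot be treated as a dependable effect of this change across the series, but two pairs do not show why the cores differ or how the change would behave on a third core.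

The compounds shown leave open which part of the difference between the two cores decides whether adding fluoro matters in this assay. They also leave open whether another group in the same place on the ring, such as a methoxy group or an amine, would give a large step on one core and none on the other, as fluoro does here.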